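The source may report more compounds than this note shows. Statements on the series, on what has been measured and on what is new or still open speak of the compounds shown alone.

Among the compounds with values here, compound 3 `Cn1nc(-c2ccccc2)c2c1OC(N)=C(C#N)C2c1ccc(OC(F)(F)F)cc1` is the one compound here that carries a number rather than a limit: in a functional assay on NCI-H2122 cells (Homo sapiens) for inhibition, read by microscopy, with a stated time of 10 days (on this read-out lower numbers stand for stronger inhibition and higher numbers for weaker inhibition), compound 3 gives 5500 nM. Compound 1 `COc1ccc(C2C(C#N)=C(N)Oc3c2c(-c2ccccc2)nn3C)cc1` sits at a limit, and in this assay compound 1 gives > 10000 nM. Compound 2 `COc1ccc(C2C(C#N)=C(N)Oc3c2c(-c2ccccc2)nn3C)cc1F` also sits at a limit, and in this assay compound 2 gives > 10000 nM. Both of those readings mark (the limit of > 10000 nM in this assay, at which 2 of the 3 values shown sit). Exchanging hydrogen for fluoro on an aromatic carbon yields a step that the two limits leave unreadable from compound 1 to compound 2. Exchanging methyl for trifluoromethyl on an oxygen on an aromatic ring yields an at least 1.8-fold lower number from compound 1 to compound 3 (0.25 log units; that floor lies within the scatter), a step whose floor lies within the scatter.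

Compound 4 `CC(C)c1ccc(C2C(C#N)=C(N)Oc3c2c(-c2ccccc2)nn3C)cc1` differs from compound 3 by isopropyl in place of trifluoromethoxy on an aromatic carbon. Within the data shown here, only that second measured step touches the same position, para to a large group, and it shows a shift of uncertain size with no firm direction for the present exchange of trifluoromethoxy for isopropyl. The unreadable first step adds nothing. For compound 4 the expectation is therefore a number close to that of compound 3, with the estimated step in this assay being a 1.1-fold higher number from compound 3 to compound 4 (0.04 log units; within the scatter). Compound 4 is estimated in this assay at 6000 nM, within a range from 2000 nM to 20000 nM.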

Compound 4, half-maximal inhibitory concentration: 5400 nM
For compound 4 the middle estimate is 1.1-fold (0.05 log units) above the measured one, within the range that was stated.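

In this assay, isopropyl in place of trifluoromethoxy, on an aromatic carbon para to a large group, gives a 1.0-fold lower number from compound 3 to compound 4 (0.01 log units; within the scatter), so the two groups cannot be told apart here, although isopropyl has no fluorine or oxygen and fewer heavy atoms. A measured number at this place therefore does not depend on fluorine in the group, since compound 4 carries none. Isopropyl in place of methoxy gives an at least 1.8-fold lower number from compound 1 to compound 4 (0.26 log units; that floor lies within the scatter), and 4-isopropylphenyl in place of 3-fluoro-4-methoxyphenyl gives an at least 1.8-fold lower number from compound 2 to compound 4 (0.26 log units; that floor lies within the scatter), but neither floor clears the scatter and the starting value of each step is a limit, not a number: the limit of > 10000 nM in this assay, at which 2 of the 4 values shown sit.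

The compounds shown leave open how far methoxy really lies from isopropyl and trifluoromethoxy, since only floors are available for those steps. They also leave open whether an amine, a carboxylic acid or a longer chain such as n-butyl at this place would move the number beyond the scatter, or whether any group here can carry the series much past the values of compound 3 and compound 4.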